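The source may report more compounds than this note shows. Statements on the series, on what has been measured and on what is new or still open speak of the compounds shown alone.

Compound 3 `COc1ccc(NC(=O)NCCCOc2cccc(CN3CCCCC3)c2)c(OC)c1` gives the highest number among the three compounds measured in an assay on isolated protein for inhibition of histamine H2 receptor (Cavia porcellus) (on this read-out lower numbers stand for tighter binding and higher numbers for weaker binding), with compound 3 at 2240 nM. Compound 2 `O=C(NCCCOc1cccc(CN2CCCCC2)c1)Nc1cccc(C(F)(F)F)c1` stands nearest to it in this assay, compound 2 giving 813 nM, and compound 1 `O=C(NCCCOc1cccc(CN2CCCCC2)c1)Nc1ccccc1` stands furthest, compound 1 giving 126 nM. The step to compound 4 `Cc1ccc(NC(=O)NCCCOc2cccc(CN3CCCCC3)c2)cc1` is 4-methylphenyl in place of 2,4-dimethoxyphenyl on an amide-type nitrogen. Among the measured compounds shown here, no measured step covers a methyl group here, so the bearing steps are those that replace the group on the same nitrogen: an 18-fold higher number from compound 1 to compound 3 (1.25 log units; beyond the scatter) and a 2.8-fold higher number from compound 2 to compound 3 (0.44 log units; beyond the scatter), both beyond the scatter, and also a 6.5-fold higher number from compound 1 to compound 2 (0.81 log units; beyond the scatter). Removing both methoxy groups and keeping a plain aromatic ring carrying only a methyl brings compound 4 closer to compound 1 than to compound 3, so a step in this assay down toward compound 1, and of a large size, is expected, though uncertainty remains over how the methyl alone acts. Compound 4 is therefore estimated at 250 nM, within 80 nM to 800 nM; the expected step is a 9.0-fold lower number from compound 3 to compound 4 (0.95 log units; beyond the scatter).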

Compound 4, dissociation constant: 631 nM
Estimate against measurement, compound 4: 2.5-fold (0.40 log units) below; the range from low to high includes it.
By their numbers in this assay, from the lowest: compound 1; then compounds 4 and 2 (each within the scatter of the next); then compound 3.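

A methyl alone on the aromatic ring already separates compound 4 from the unsubstituted phenyl, with a 5.0-fold higher number from compound 1 to compound 4 (0.70 log units; beyond the scatter) in this assay, so even this single small addition counts at this position. Leaving the 2,4-dimethoxyphenyl for 4-methylphenyl gives a 3.5-fold lower number from compound 3 to compound 4 (0.55 log units; beyond the scatter) and recovers only part of what compound 3 lost, while a 1.3-fold lower number from compound 2 to compound 4 (0.11 log units; within the scatter) means that 4-methylphenyl and 3-(trifluoromethyl)phenyl cannot be told apart here. All three substituted rings therefore give higher numbers than the plain phenyl of compound 1, and no data on hand explain why.

The compounds shown leave open whether either methoxy group alone accounts for the number of compound 3. They also leave open whether a chlorine or an amine on this ring would behave like the methyl.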